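The compounds below may be only part of what the source reports. "The series", "measured", "known", "first", "only" and "open" are said of these compounds alone.

Values in a functional assay for inhibition, with Homo sapiens as the target; a lower number here means a stronger inhibitor, a higher number a weaker inhibitor:

compound 1 `CNc1ccc(Nc2nccc(-c3cccnc3)n2)cc1`: 2100 nM
compound 2 `COc1cccc(Nc2nccc(-c3cc4ccccc4o3)n2)c1`: 2800 nM
compound 3 `COc1cccc(Nc2nc(C)cc(-c3ccncc3)n2)c1`: > 24000 nM, a limit of the assay, not a number

Compound 1 gives the lower of the two numbers, and compound 2 sits within the usual scatter of it, so no order between the two is claimed. Compound 3 reaches only (the limit of > 24000 nM in this assay, at which 1 of the 3 values shown sits).

Compound 4 `c1cncc(-c2ccnc(Nc3ccc(-n4ccnc4)cc3)n2)c1` differs from compound 1 in one place: 1H-imidazol-1-yl in place of methylamino on an aromatic carbon. Within the data shown here, no step between measured compounds covers a change of this kind, so the expectation rests on compound 1 alone, which gives 2100 nM in this assay. For this change a step in this assay no larger than the scatter is expected, in either direction. Compound 4 is therefore estimated at 2500 nM, within a range of 700 nM to 9000 nM. The expected step of a 1.2-fold higher number from compound 1 to compound 4 (0.08 log units; within the scatter) is thus estimated to stay within the usual scatter.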

Compound 4, half-maximal inhibitory concentration: 1300 nM
Estimate against measurement, compound 4: 1.9-fold (0.28 log units) above; low and high end bracket the measured number.
By their numbers in this assay, from the lowest: compounds 4, 1 and 2 (each within the scatter of the next, the first and the last beyond it). At a limit, above all of these: compound 3.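

At this place, on an aromatic carbon para to a large group, 1H-imidazol-1-yl in place of methylamino gives a 1.6-fold lower number from compound 1 to compound 4 (0.21 log units; within the scatter) in this assay. The position therefore accepts a five-membered aromatic ring with 0 hydrogen-bond donors in place of a group with 1, and the number stays within the scatter. No measured property at hand bears on this step.

From the compounds shown here alone, whether a carboxylic acid or a dimethylamino group at this place would hold the number remains open. So does whether any group here can move it beyond the scatter.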